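The source may report more compounds than this note shows. Statements on the series, on what has been measured and on what is new or still open speak of the compounds shown alone.

Compound 1, with the structure `CCOC(=O)C1=CCCCC1S(=O)(=O)Nc1ccccc1`, gives 260 nM in a functional assay on RAW264.7 cells (Mus musculus) for inhibition; a higher number here means a weaker inhibitor, a lower number a stronger inhibitor. On the numbers shown, compound 1 stands at the highest of the two measured, though its only neighbour, compound 2, with the structure `CCOC(=O)C1=CCCCC1S(=O)(=O)Nc1cccc(F)c1`, gives 150 nM, and the step of a 1.7-fold lower number from compound 1 to compound 2 (0.24 log units; within the scatter) does not leave the usual scatter of this assay.

Compound 3, with the structure `CCOC(=O)C1=CCCCC1S(=O)(=O)Nc1ccc(F)cc1`, has not yet been measured. It differs from compound 1 by fluoro in place of hydrogen on an aromatic carbon. Among the measured compounds shown here, the only measured step that bears on this change is the one from compound 1 to compound 2, which is the same kind of exchange, fluoro in place of hydrogen on an aromatic carbon, and it amounted to a 1.7-fold lower number from compound 1 to compound 2 (0.24 log units; within the scatter). On that single precedent no step beyond the scatter is expected for compound 3; if anything, a slightly lower number is expected, as a step of a 1.3-fold lower number from compound 1 to compound 3 (0.11 log units; within the scatter). Compound 3 is therefore estimated to give 200 nM in this assay, with a range from 100 nM to 400 nM.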

Compound 3, half-maximal inhibitory concentration: 110 nM
For compound 3 the middle estimate is 1.8-fold (0.26 log units) above the measured one; the range from low to high includes it.
By their numbers in this assay, from the lowest: compounds 3, 2 and 1 (each within the scatter of the next, the first and the last beyond it).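

In this assay, fluoro in place of hydrogen on an aromatic carbon, para to a large group, gives a 2.4-fold lower number from compound 1 to compound 3 (0.37 log units; beyond the scatter) and so makes this the first exchange of its kind among these compounds to pass beyond the scatter, although the step remains a modest one. Placement of the fluoro, by contrast, is not resolved by these data: 4-fluorophenyl in place of 3-fluorophenyl on the sulfonamide nitrogen gives a 1.4-fold lower number from compound 2 to compound 3 (0.13 log units; within the scatter) and leaves the two fluorinated compounds indistinguishable in this measurement, so only the 4-fluorophenyl compound stands clearly apart from the unsubstituted phenyl compound. No measurement available here accounts for the size of the step or for the lack of a separation between the two fluoro placements.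

The compounds shown leave open whether the step belongs to fluoro alone or would also appear with chloro, methoxy or an amine on the same aromatic carbon. They also leave open whether it would persist if the ethyl ester of the shared core gave way to a carboxylic acid or an amide.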